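From methyl to chloro on the shared core

The compounds below may be only part of what the source reports. "The series", "measured", "known", "first", "only" and "open" are said of these compounds alone.

In an ADME assay on microsomes from liver (Homo sapiens) for metabolic stability, read by LC-MS, using NADPH, tested at 1 uM (a lower number here means slower removal, a higher number faster removal of the compound), compound 1 `N#Cc1cnc(NC(=O)CCCOc2ccccc2)s1` gives 198 mL.min-1.g-1 and compound 2 `Cc1cnc(NC(=O)CCCOc2ccccc2)s1` gives 175 mL.min-1.g-1 so these two stand within the scatter of each other. Compound 3 `O=C(CCCOc1ccccc1)Nc1ncc(Cl)s1` differs from compound 2 at one place, with chloro in place of methyl on an aromatic carbon and the rest of the structure unchanged. Within the data shown here, only one measured step bears on this place: a 1.1-fold lower number from compound 1 to compound 2 (0.05 log units; within the scatter) as methyl took the place of cyano. Chloro itself has no measured value on this core, so that single step is thin guidance. Still, with no step beyond the scatter seen here, none is expected for this swap in this assay either. The estimated step is a 1.0-fold higher number from compound 2 to compound 3 (0.01 log units; within the scatter) and so amounts to no expected change. Compound 3 is estimated at 180 mL.min-1.g-1 with a range from 100 mL.min-1.g-1 to 320 mL.min-1.g-1 as the expected outcome.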

Compound 3, intrinsic clearance in microsomes: 90 mL.min-1.g-1
Compound 3: middle estimate off by 2.0-fold (0.30 log units), on the high side; measured number below the stated range.
By their numbers in this assay, from the lowest: compounds 3, 2 and 1 (each within the scatter of the next, the first and the last beyond it).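

In this assay, among these compounds, this place on the shared core turns out not to be silent: a 2.2-fold lower number from compound 1 to compound 3 (0.34 log units; beyond the scatter), the first step here to pass beyond the scatter, though only modestly. Meanwhile a 1.9-fold lower number from compound 2 to compound 3 (0.29 log units; within the scatter), so chloro and methyl cannot be told apart, and compound 2 sits within the scatter of both compound 1 and compound 3, which means only the two end members of this short series separate clearly. Nothing measured here explains the gap between the nitrile and the chloro compound.

On these data alone, whether a bromo, a trifluoromethyl or an amine at this place would extend that gap or fall inside it remains open. As far as these compounds go, it is equally open whether the chloro step would hold with a longer chain in place of the one shared here.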